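Replacing cyclohexyl by a phenoxy group on the shared core

The compounds below may be only part of what the source reports. "The series", "measured", "known", "first", "only" and "open" are said of these compounds alone.

Measured compounds:
compound 1 `COc1ccc(F)cc1CNCCCNc1ccnc2cc(C3CCCCC3)ccc12` — 4200 nM
compound 2 `c1coc(CNCCCNc2ccnc3cc(C4CCCCC4)ccc23)c1` — 4200 nM
compound 3 `Clc1ccc(Oc2ccc3c(NCCCNCc4ccco4)ccnc3c2)cc1` — 14500 nM

In a physicochemical assay for solubility, with a stated time of 18 h, at pH 7.4 (on this read-out lower numbers stand for lower solubility and higher numbers for higher solubility), compound 1 stands level with compound 2 at the digits printed, and the two of them give the lowest of the three numbers; the step of no change at the digits printed from compound 1 to compound 2 (within the scatter) lies within the scatter, while compound 3 sits furthest away. Compound 4 `COc1ccc(F)cc1CNCCCNc1ccnc2cc(Oc3cccc(N(C)C)c3)ccc12` differs from compound 1 as follows: 3-(dimethylamino)phenoxy in place of cyclohexyl on an aromatic carbon. Within the data shown here, the one measured step that bears on this is a 3.5-fold higher number from compound 2 to compound 3 (0.54 log units; beyond the scatter), where an aryl ether likewise took the place of cyclohexyl on the same aromatic carbon. A step of similar size and direction is therefore expected in this assay. Compound 4 is estimated at 13000 nM, with a range of 5000 nM to 35000 nM, a step of a 3.1-fold higher number from compound 1 to compound 4 (0.49 log units; beyond the scatter).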

Compound 4, solubility: 14500 nM
The estimate for compound 4 lay 1.1-fold (0.05 log units) below the measured number; the range from low to high includes it.
By their numbers in this assay, from the lowest: compounds 1 and 2 (each within the scatter of the next); then compounds 3 and 4 (each within the scatter of the next).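

In this assay the step of a 3.5-fold higher number from compound 1 to compound 4 (0.54 log units; beyond the scatter) shows that an aryl ether in place of cyclohexyl on this aromatic carbon gives a higher number with 5-fluoro-2-methoxyphenyl on the chain, not only with furan-2-yl. This step matches a 3.5-fold higher number from compound 2 to compound 3 (0.54 log units; beyond the scatter) in size, although 3-(dimethylamino)phenoxy has replaced 4-chlorophenoxy as the aryl ether. Nothing given here accounts for the change. Open, going by these compounds, is whether unsubstituted phenoxy or a piperidine on this carbon would give a similar step, and whether the step would persist with a longer chain between the amines.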